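The source may report more compounds than this note shows. Statements on the series, on what has been measured and on what is new or still open speak of the compounds shown alone.

In an ADME assay on THP-1 cells (Homo sapiens) for cytotoxicity, read by flow cytometry and propidium iodide staining, with a stated time of 72 h (a higher number here means a weaker inhibitor, a lower number a stronger inhibitor), compound 2 `COc1ccc(-c2oc3ccc(NC(C)=O)cc3c(=O)c2O)cc1` gives 9000 nM, the lowest of three numbers, while compound 3 `CC(=O)Nc1ccc2oc(-c3ccc(F)cc3)c(O)c(=O)c2c1` gives 26000 nM and compound 1 `COc1cccc(-c2oc3ccc(NC(C)=O)cc3c(=O)c2O)c1` gives 50000 nM. Compound 4 `COc1ccc(-c2oc3ccc(N)cc3c(=O)c2O)cc1` keeps the 4-methoxyphenyl group of compound 2 but turns acetamido to amino: hydrogen in place of acetyl on a nitrogen on an aromatic ring. Within the data shown here, no measured step touches this nitrogen. The nearest guides are changes on the phenyl group, a 5.6-fold lower number from compound 1 to compound 2 (0.74 log units; beyond the scatter) and a 2.9-fold higher number from compound 2 to compound 3 (0.46 log units; beyond the scatter), and both are modest. They suggest how far numbers in this small series can move, but give no direction for the new change, so no step beyond the scatter is expected. The estimated result is a 1.5-fold lower number from compound 2 to compound 4 (0.18 log units; within the scatter). Compound 4 is expected at 6000 nM, with an estimated range from 1500 nM to 25000 nM.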

Compound 4, half-maximal inhibitory concentration: 29000 nM
Compound 4: middle estimate off by 4.8-fold (0.68 log units), on the low side; measured number outside the range, above it.
By their numbers in this assay, from the lowest: compound 2; then compounds 3, 4 and 1 (each within the scatter of the next).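

This nitrogen on an aromatic ring now has a first reading: in this assay, hydrogen in place of acetyl gives a 3.2-fold higher number from compound 2 to compound 4 (0.51 log units; beyond the scatter). The acetyl group therefore counts for something here, and its loss moves the number in the direction of a weaker inhibitor, though this rests on a single pair with the 4-methoxyphenyl group in place. Nothing shown explains the step. Still open, as far as these compounds go, is whether the same change gives a similar step with 4-fluorophenyl on the core, and how a longer acyl chain such as butanoyl on this nitrogen would read.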